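Replacing the benzothiophene acid with an indane acid

The source may hold more compounds than are shown below. What is called first, only, known or untested is meant among the compounds shown, and "the series" means these compounds.

Measured compounds:
Compound 1, `CC(C)c1onc(-c2c(Cl)cccc2Cl)c1COc1ccc(Sc2cccc3sc(C(=O)O)cc23)cc1`, gives 59% in a functional assay on CV-1 cells for agonist activity at Bile acid receptor (Homo sapiens), read by a luciferase reporter; on this read-out higher numbers stand for larger maximal responses and lower numbers for smaller maximal responses.
Compound 2, `CC(C)c1onc(-c2c(Cl)cccc2Cl)c1COc1ccc(-c2ccc3sc(C(=O)O)cc3c2)cc1`, gives 91% in this assay.

Of the two numbers shown, compound 2 stands highest, and compound 1 lies beyond the scatter below it. Compound 3, `CC(C)c1onc(-c2c(Cl)cccc2Cl)c1COc1ccc(-c2ccc3c(c2)CC(C(=O)O)C3)cc1`, is not yet measured. It differs from compound 2 by 2-carboxy-2,3-dihydro-1H-inden-5-yl in place of 2-carboxy-1-benzothiophen-5-yl on an aromatic carbon. Among the compounds with values here, no measured pair shows this change, so the expected step is a guess; a moderate loss of maximal response is expected, with a sizeable range around it. The estimated step of a number 26 percentage points lower from compound 2 to compound 3 (beyond the scatter) goes downward. Compound 3 is therefore expected to reach about 65%, between 30% and 100%.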

Compound 3, largest response reached (Emax), in percent of the reference or control that the assay uses: 59%
Estimate against measurement, compound 3: 6 percentage points above; the range from low to high includes it.
By their numbers in this assay, from the lowest: compounds 1 and 3 (each within the scatter of the next); then compound 2.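

Replacing 2-carboxy-1-benzothiophen-5-yl with 2-carboxy-2,3-dihydro-1H-inden-5-yl, which has the same number of heavy atoms, gives a number 32 percentage points lower from compound 2 to compound 3 (beyond the scatter) in this assay. At this position, para to a large group, the maximal response therefore depends on the ring carrying the carboxylic acid, not on the presence of the acid alone. Nothing measured here explains the loss.

The change removes the sulfur and the aromatic five-membered ring together, and the compounds shown do not separate the two. They also leave open how a tetrazole in place of the carboxylic acid would behave.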